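The source may report more compounds than this note shows. Statements on the series, on what has been measured and on what is new or still open speak of the compounds shown alone.

Compound 1 `C=CCCC(=O)N[C@H]1[C@@H](OCCCCCCCCCCCCCCCC)O[C@H](CO)[C@@H](O)[C@@H]1O` gives > 50 uM, a limit of the assay rather than a number.
Compound 2 `CCCCC(=O)N[C@H]1[C@@H](OCCc2ccccc2)O[C@H](COCC(CO)(CO)COS(=O)(=O)O)[C@@H](O)[C@@H]1O` gives 6.7 uM.
Compound 3 `CCCCC(=O)N[C@H]1[C@@H](OCCc2ccccc2)O[C@H](COCC(CO)(CO)CO)[C@@H](O)[C@@H]1O` gives > 50 uM, again only a limit.

These values come from a functional assay on U-373MG ATCC cells (Homo sapiens), read by thymidine incorporation; a higher number here means a weaker inhibitor, a lower number a stronger inhibitor. Between compound 3 and compound 2 the change is sulfo in place of hydrogen on an oxygen on a saturated carbon, and it brings an at least 7.4-fold lower number from compound 3 to compound 2 (0.87 log units; beyond the scatter). How the core of compound 1 differs from that of compound 3 is not broken down here.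

Compound 4 `C=CCCC(=O)N[C@H]1[C@@H](OCCCCCCCCCCCCCCCC)O[C@H](CO)[C@@H](O)[C@@H]1OS(=O)(=O)O` differs from compound 1 by sulfo in place of hydrogen on an oxygen on a saturated carbon. The place is not the same word for word: for compound 2 the oxygen sits on a carbon whose other neighbour is a saturated chain carbon, whereas for compound 4 it is a saturated ring carbon, so this is the same kind of change, not the same change. For compound 1 only a limit is known, described by the limit of > 50 uM in this assay, at which 2 of the 3 values shown sit, so the starting point is uncertain. A step of about an at least 3.3-fold lower number from compound 1 to compound 4 (0.52 log units; beyond the scatter) is expected, resting on the measured step from compound 3 to compound 2 and on the limit of compound 1. Compound 4 is therefore estimated at 15 uM, expected between 3 uM and 60 uM.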

Compound 4, concentration for 50% inhibition: 33 uM
For compound 4 the middle estimate is 2.2-fold (0.34 log units) below the measured one, and the stated range covers the measured number.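

In this assay compound 1 gives > 50 uM, which is a limit of the assay and not a number. On this core, sulfo in place of hydrogen can therefore be read only as a floor, an at least 1.5-fold lower number from compound 1 to compound 4 (0.18 log units; that floor lies within the scatter), so the change points the same way as on the other core but is not shown to exceed the usual scatter here. Whether it carries over at full size stays unsettled: the same change on two cores in this assay, an at least 7.4-fold lower number (0.87 log units; beyond the scatter) from compound 3 to compound 2 and an at least 1.5-fold lower number (0.18 log units; that floor lies within the scatter) from compound 1 to compound 4; the limit leaves it open whether they differ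

The compounds shown leave open the true reading of compound 1, and so the real size of this step. They also leave open whether a carboxylic acid in place of sulfo, on the same oxygen, would lower the number too.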